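Changing the carboxy-bearing amide group of compound 2

The source may report more compounds than this note shows. Statements on the series, on what has been measured and on what is new or still open speak of the compounds shown alone.

In a functional assay on PC-3 cells (Homo sapiens), read by MTT assay, with a stated time of 48 h (a higher number here means a weaker inhibitor, a lower number a stronger inhibitor), compound 2 (`CC[C@@H](C)[C@H](NC(=O)c1ccc(C(CC)(CC)c2ccc(OCC(O)C(C)(C)C)c(C)c2)n1CC)C(=O)O`) gives 1900 nM and holds the lower of the two numbers, while compound 1 (`CCn1c(C(=O)NCC(OC)OC)ccc1C(CC)(CC)c1ccc(OCC(O)C(C)(C)C)c(C)c1`) gives 14600 nM on the same read-out. Compound 3 (`CCn1c(C(=O)N(C)CC(=O)O)ccc1C(CC)(CC)c1ccc(OCC(O)C(C)(C)C)c(C)c1`) differs from compound 2 at one place ((carboxymethyl)(methyl)amino in place of (1-carboxy-2-methylbutyl)amino on a carbonyl carbon) and still carries a carboxy group. Among the compounds with values here, the only measured step (a 7.7-fold lower number from compound 1 to compound 2 (0.89 log units; beyond the scatter)) introduced 1-carboxy-2-methylbutyl and is an indirect guide: no measured pair compares two carboxy-bearing groups. An estimated 2.4-fold higher number from compound 2 to compound 3 (0.37 log units; beyond the scatter) is expected in this assay and would be smaller than that measured step. Compound 3 is estimated at 4500 nM with an expected range of 1300 nM to 14000 nM on this evidence.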

Compound 3, half-maximal inhibitory concentration: 23900 nM
For compound 3 the middle estimate is 5.3-fold (0.73 log units) below the measured one; the measured number lies above the stated range.
By their numbers in this assay, from the lowest: compound 2; then compounds 1 and 3 (each within the scatter of the next).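

In this assay, keeping a carboxy group does not preserve the number of compound 2: (carboxymethyl)(methyl)amino in place of (1-carboxy-2-methylbutyl)amino on this carbonyl carbon gives a 13-fold higher number from compound 2 to compound 3 (1.10 log units; beyond the scatter) at this position. A carboxy group alone therefore does not set compound 2 apart, as (carboxymethyl)(methyl)amino in place of (2,2-dimethoxyethyl)amino gives a 1.6-fold higher number from compound 1 to compound 3 (0.21 log units; within the scatter) and stays level. No available measurement accounts for the size of these steps.

As far as these compounds go, the side chain, the stereocentres and the amide hydrogen all change together from compound 2 to compound 3, so their separate contributions remain open. A simple (carboxymethyl)amino group, or a sec-butyl chain ending in a primary amide instead of the carboxylic acid, would bear on this.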